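Sec-butylsulfanyl for Propylsulfanyl: Tolerated Concentration Expected

This account rests on a few compounds, and the source may have more. Where it says the series, first, only, none or still open, it means among the compounds named here.

Compound 1 `CCCSc1nc(C(C)c2c(F)cccc2Cl)c(CC)c(=O)[nH]1`: > 3000 nM
Compound 2 `CCc1c(C(C)c2c(F)cccc2Cl)nc(SC(C)CC)[nH]c1=O`: > 3000 nM
Compound 3 `CCCSc1nc(C(CC)c2c(F)cccc2F)c(C)c(=O)[nH]1`: > 3000 nM

Of the compounds shown here, three have been measured in an ADME assay on MT4 cells (Homo sapiens) for activation, read by MTT assay; a higher number here means that more compound is tolerated, a lower number that less compound is tolerated. Compound 1 gives > 3000 nM, which is a limit of the assay and not a number. Compound 2 likewise gives > 3000 nM, again a limit. Compound 3 gives > 3000 nM, also a limit. The change from compound 1 to compound 2 is methyl in place of hydrogen on a saturated chain carbon bound to a saturated chain carbon and a sulfur, and it makes a step that the two limits leave unreadable from compound 1 to compound 2. The cores of compound 1 and compound 3 differ in more than one place; that difference is not broken down here. Compound 4 `CCC(C)Sc1nc(C(CC)c2c(F)cccc2F)c(C)c(=O)[nH]1` has not yet been measured. It stands to compound 3 exactly as compound 2 stands to compound 1, the same change at the same place: methyl in place of hydrogen on a saturated chain carbon bound to a saturated chain carbon and a sulfur. Among the compounds with values here, every measured value so far sits at the limit of > 3000 nM in this assay, at which 3 of the 3 values shown sit. In this assay the expected step is a step that the limit leaves unreadable from compound 3 to compound 4, and that expectation rests on (the limit of > 3000 nM in this assay, at which 3 of the 3 values shown sit), where compound 3 already sits. Compound 4 is therefore estimated at 5000 nM, between 3000 nM and 20000 nM, most likely reported once more as a limit.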

Compound 4, half-maximal cytotoxic concentration: > 3000 nM
Compound 4: only a limit was reported; the forecaster's own chance of this, stated with the estimate: 85%; the middle value lies beyond the limit too.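

No step can be read from compound 3 to compound 4, because in this assay compound 4, like compound 3, gives a limit and not a number: the limit of > 3000 nM in this assay, at which 4 of the 4 values shown sit. The compounds shown leave open how much of any of them is tolerated beyond that limit, and whether propylsulfanyl and (sec-butyl)sulfanyl differ at all.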